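From Trifluoromethyl to Chloro: What Compound 4 Might Show

A few compounds are considered here, and "the series" means these few. Any claim that something is new, unique, unknown or untested is made for them only; others in the source may bear on it.

Of the compounds shown here, three built on one shared core have been tested in a functional assay on the whole organism (strain CD1) with Mus musculus as the target, with a stated time of 0.5 h (a higher number here means that more compound is needed for the effect, a lower number that less compound is needed), differing only in the substituent pattern of the aromatic ring carried on an amine nitrogen in a ring. Compound 1 `Cc1cccc(N2CCN(C(=O)CN3C(=O)CC(C)C3=O)CC2)c1` gives 100 mg/kg. Compound 2 `CC1CC(=O)N(CC(=O)N2CCN(c3ccc(Cl)c(Cl)c3)CC2)C1=O` gives 100 mg/kg. The step of no change at the digits printed from compound 1 to compound 2 (within the scatter) therefore shows that two chloro groups in place of a methyl leave the number where it was. Compound 3 `CC1CC(=O)N(CC(=O)N2CCN(c3cccc(C(F)(F)F)c3)CC2)C1=O` gives 300 mg/kg, the highest of the three numbers. The step of a 3.0-fold higher number from compound 1 to compound 3 (0.48 log units; beyond the scatter) is the only one in the set that moves the read-out beyond the scatter.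

Compound 4 `CC1CC(=O)N(CC(=O)N2CCN(c3cccc(Cl)c3)CC2)C1=O` has not yet been measured. Its change from compound 3 is chloro in place of trifluoromethyl on an aromatic carbon. Both measured steps bear on it: the trifluoromethyl that raised the number in compound 3 leaves, and a chloro, which in compound 2 cost nothing, enters. The step is therefore expected to be a 3.0-fold lower number from compound 3 to compound 4 (0.48 log units; beyond the scatter), a return toward the level of compounds 1 and 2. Compound 4 is estimated at 100 mg/kg, with a range from 50 mg/kg to 300 mg/kg.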

Compound 4, minimum effective dose: 100 mg/kg
Compound 4: the middle estimate sits on the measured number at the digits printed; low and high end bracket the measured number.
By their numbers in this assay, from the lowest: compounds 1, 2 and 4 (each within the scatter of the next); then compound 3.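

In this assay, chloro in place of trifluoromethyl on this aromatic carbon, meta to a large group, gives a 3.0-fold lower number from compound 3 to compound 4 (0.48 log units; beyond the scatter), which ties the higher number of compound 3 to trifluoromethyl itself rather than to having any substituent at this place. Chloro and methyl at this place cannot be told apart, with no change at the digits printed from compound 1 to compound 4 (within the scatter), and hydrogen in place of the other chloro of compound 2 gives no change at the digits printed from compound 2 to compound 4 (within the scatter), so among these four compounds only trifluoromethyl stands apart. Nothing available here explains why trifluoromethyl alone separates from the others.

The compounds shown leave open whether a methoxy, an amine or a carboxylic acid at this place would stay with chloro and methyl or move the number as trifluoromethyl does. They also leave open whether the gap seen with trifluoromethyl would persist at another stated time.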